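Oxanyl ether in place of oxolanylmethylamine on the nitroaryl

The source may report more compounds than this note shows. Statements on the series, on what has been measured and on what is new or still open speak of the compounds shown alone.

Going by the values given here, compound 3 `CC1(C)CCC(CN2CCN(c3ccc(C(=O)NS(=O)(=O)c4ccc(NCC5CCOC5)c([N+](=O)[O-])c4)c(Oc4cnc5[nH]ccc5c4)c3)CC2)=C(c2ccc(C(F)(F)F)cc2)C1` stands at the high end of the three numbers measured so far: in an assay on isolated protein for displacement of a labelled ligand from Apoptosis regulator Bcl-2 (Homo sapiens), with a stated time of 15 min (on this read-out higher numbers stand for weaker inhibition and lower numbers for stronger inhibition), compound 3 gives 4.7 nM on this read-out. Compound 1 `COc1ccc(C2=C(CN3CCN(c4ccc(C(=O)NS(=O)(=O)c5ccc(NCC6CCOCC6)c([N+](=O)[O-])c5)c(Oc5cnc6[nH]ccc6c5)c4)CC3)CCC(C)(C)C2)cc1` gives 3.8 nM in this assay, a gap from compound 3 that lies within the scatter, whereas compound 2 `CC1(C)CCC(CN2CCN(c3ccc(C(=O)NS(=O)(=O)c4ccc(NCC5CCOCC5)c([N+](=O)[O-])c4)c(Oc4cnc5[nH]ccc5c4)c3)CC2)=C(c2ccc(C(F)(F)F)c(Cl)c2)C1` gives 0.8 nM in this assay, a number beyond the scatter lower than that of compound 3. Among the compounds with values here, the single measured step, a 4.8-fold lower number from compound 1 to compound 2 (0.68 log units; beyond the scatter), concerns the aryl on the double-bonded ring carbon and alters nothing at the sulfonyl-bearing aromatic ring.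

Compound 4 `CC(Oc1ccc(S(=O)(=O)NC(=O)c2ccc(N3CCN(CC4=C(c5ccc(C(F)(F)F)cc5)CC(C)(C)CC4)CC3)cc2Oc2cnc3[nH]ccc3c2)cc1[N+](=O)[O-])C1CCOCC1` differs from compound 3 in a different region of the molecule: a group of 9 heavy atoms (7 carbon, 2 oxygen; one six-membered non-aromatic ring with 1 hetero atom) in place of a group of 7 heavy atoms (5 carbon, 1 nitrogen, 1 oxygen; one five-membered non-aromatic ring with 1 hetero atom), on an aromatic carbon. An ether oxygen thus replaces the amino linkage, and the six-membered ring replaces the five-membered one. Within the data shown here, no measured pair in this set varies that position, so the one measured step does not bear on it, and the data give no direction for the change. The step is therefore expected to be a 1.1-fold higher number from compound 3 to compound 4 (0.03 log units; within the scatter), not beyond the scatter. Compound 4 is estimated at 5 nM in this assay, with an expected range from 1.5 nM to 16 nM.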

Compound 4, half-maximal inhibitory concentration: 9.2 nM
Compound 4: the middle estimate sits 1.8-fold (0.26 log units) below what was measured, within the range that was stated.
By their numbers in this assay, from the lowest: compound 2; then compounds 1, 3 and 4 (each within the scatter of the next, the first and the last beyond it).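

Going by these compounds alone, this is the first measured change at the position ortho to a nitro group and para to a large group, and in this assay it gives a 2.0-fold higher number from compound 3 to compound 4 (0.29 log units; within the scatter). So this position accepted a double exchange, of linking atom and ring size together, without a step beyond the scatter, even though the ((oxolan-3-yl)methyl)amino group that leaves carries 1 hydrogen-bond donor and the group that enters carries 0. In this pair, then, the amino hydrogen-bond donor at this position is not required for a number in the same range on this read-out, although one pair at one position supports no general rule. No measurement offered here explains why the exchange leaves the number within the scatter.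

Since the linking atom and the ring change in the same step, the compounds shown leave open what each of the two contributes on its own, and the step may hide opposing contributions. They also leave open how this position would respond to a morpholine ring, a cyclohexane ring without a ring oxygen or an open methoxyethyl chain in place of the rings seen here.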